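The source may hold more compounds than are shown below. What is called first, only, known or untested is meant among the compounds shown, and "the series" means these compounds.

Compound 2 `COc1ccc(CS(=O)(=O)/C=C/c2ccc(OC)c(OC)c2OC)cc1[N+](=O)[O-]` carries a nitro group on the shared core. Going by the values given here, in a functional assay on HCT-116 cells (Homo sapiens) for cytotoxicity, read by MTT assay, with a stated time of 72 h (a higher number here means a weaker inhibitor of growth, a lower number a stronger inhibitor of growth), compound 2 gives 27900 nM, and this is the only numerical value in the small set examined here. Compound 1 `COc1cc(OC)c(/C=C/S(=O)(=O)Cc2ccc(OC)c(N)c2)c(OC)c1`, which carries an amino group on a differently substituted core, gives < 10 nM in this assay, and that reading is a limit of the assay rather than a number. Compound 1 sits at the limit (the limit of < 10 nM in this assay, at which 1 of the 2 values shown sits). Compound 3 `COc1ccc(CS(=O)(=O)/C=C/c2ccc(OC)c(OC)c2OC)cc1N` has not yet been measured. It differs from compound 2 by amino in place of nitro on an aromatic carbon. Among the compounds with values here, no measured pair isolates exactly this change; its size is open. The step is expected to be a large gain in growth inhibition, estimated as a 56-fold lower number from compound 2 to compound 3 (1.75 log units; beyond the scatter). Compound 3 is expected to give roughly 500 nM in this assay, most likely somewhere between 30 nM and 8000 nM.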

Compound 3, concentration for 50% growth inhibition: 5310 nM
Beside the measured number, compound 3's estimate is 11-fold (1.03 log units) below it, within the range that was stated.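

In this assay, the exchange of nitro for amino on this aromatic carbon, ortho to a methoxy group, can now be read on its own, with the rest of the shared core unchanged: it gives a 5.3-fold lower number from compound 2 to compound 3 (0.72 log units; beyond the scatter). Compounds 1 and 2 differ in more than this one place, so that pair could not isolate the change. The gain lies beyond the scatter but is modest, and with the amino group in place compound 3 gives 5310 nM.

As far as these compounds go, what a hydroxyl group or a methylamino group would do on this same aromatic carbon stays open, as does the part played by the differently substituted core of compound 1. The reading of compound 1 is a limit and not a number: the limit of < 10 nM in this assay, at which 1 of the 3 values shown sits.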